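The source may hold more compounds than are shown below. What is called first, only, known or untested is meant among the compounds shown, and "the series" means these compounds.

The study examines two piperazine amides in a functional assay on the whole organism (strain Swiss) with Mus musculus as the target, in the maximal electroshock model, with a stated time of 1 h, at a dose of 100 mg/kg by the intraperitoneal route; a higher number here means a stronger effect of the compound at the dose given, a lower number a weaker effect. Compound 1, of structure `COCC(C(=O)N1CCN(c2cccc(C(F)(F)F)c2)CC1)N1C(=O)CCC1=O`, gives 50% in this assay. Compound 2, of structure `CC(C(=O)N1CCN(c2cccc(Cl)c2)CC1)N1C(=O)CCC1=O`, gives 50% in this assay. On these numbers compound 2 stands level with compound 1 at the digits shown; the two values fall within the usual scatter of each other, so nothing can be said of an order between them.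

Compound 3, of structure `CC(C(=O)N1CCN(c2ccccc2)CC1)N1C(=O)CCC1=O`, has not yet been tested in this assay. It differs from compound 2 in one place: hydrogen in place of chloro on an aromatic carbon. Within the data shown here, no measured pair in this set shows the same change, so its effect cannot be read from a neighbouring step. Since compound 1 and compound 2 carry different groups on that ring yet give the same reading, the author expects the step of a number 10 percentage points lower from compound 2 to compound 3 (within the scatter) to be small, with at most a slight loss that stays close to the scatter. For compound 3 the estimated activity in this assay is 40%, with a plausible range from 0% to 75%.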

Compound 3, a percentage reported as activity, at one dose (the size of the read-out at that dose, not a potency): 0%
The estimate for compound 3 lay 40 percentage points above the measured number, within the range that was stated.
By their numbers in this assay, from the lowest: compound 3; then compounds 1 and 2 (each within the scatter of the next).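

In this assay, hydrogen in place of chloro on an aromatic carbon gives a number 50 percentage points lower from compound 2 to compound 3 (beyond the scatter), so this one place on the ring, meta to a large group, matters to the read-out. The earlier compounds shown here could not show this, as they differ from each other in more than one place and their equal readings said nothing about any single group. With the chloro gone, compound 3 gives 0% at the dose used, so the reading of compound 2 depends on a group being present at this place on the shared core, though nothing measured here bears on why the step is so large.

On these data alone, whether chloro itself is needed, or whether another group at the same place, such as fluoro, methoxy or an amine, would restore the reading, remains open. The trifluoromethyl group appears only in compound 1, which also differs from compound 2 in its chain, so its contribution cannot be separated, and a reading at a single dose gives no measure of potency for any of the three compounds.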